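Adding a Methoxy to Compound 1

The source may hold more compounds than are shown below. What is called first, only, known or untested is meant among the compounds shown, and "the series" means these compounds.

Compound 1 (`COc1ccc(C2=N[C@@H](C(=O)O)CS2)c(O)c1`) gives -0.89 in a physicochemical assay for lipophilicity; a higher number here means a more lipophilic compound, a lower number a more polar compound
Compound 2 (`C[C@]1(C(=O)O)CSC(c2cc(O)ccc2O)=N1`) gives -1.14 in this assay
Compound 3 (`O=C(O)[C@H]1CSC(c2ccc(O)cc2O)=N1`) gives -1.33 in this assay

Compound 1 shares the upper end of this small set with compound 2, the two lying within the scatter of each other, while compound 3 lies beyond it. Compound 4 (`COc1ccc(C2=N[C@@H](C(=O)O)CS2)c(O)c1OC`) has methoxy in place of hydrogen on an aromatic carbon of the core of compound 1 (methoxy in place of hydrogen on an aromatic carbon), ortho to a hydroxy group and ortho to a methoxy group. For the measured compounds named here, one measured step bears on this: with hydrogen in place of methyl on an oxygen on an aromatic ring, the number moves a number 0.44 log units lower from compound 1 to compound 3 (beyond the scatter) in a modest step. Here a methoxy is gained instead, so a small rise in this assay is expected, and the expected a number 0.14 log units higher from compound 1 to compound 4 (within the scatter) stays within the scatter. The estimated value for compound 4 is -0.75 (expected range -1.15 to -0.4).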

Compound 4, partition coefficient: -1.28
The estimate for compound 4 lay 0.53 log units above the measured number, outside the stated range (below it).
By their numbers in this assay, from the lowest: compounds 3, 4, 2 and 1 (each within the scatter of the next, the first and the last beyond it).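

In this assay, gaining a methoxy on this aromatic carbon, ortho to a hydroxy group and ortho to a methoxy group, lowers the number (a number 0.39 log units lower from compound 1 to compound 4 (beyond the scatter)). The step does not mirror the earlier one, in which hydrogen replaced methyl on an oxygen (a number 0.44 log units lower from compound 1 to compound 3 (beyond the scatter)): gaining a methoxy here and losing that methyl both go lower. Nothing available explains this direction.

Going by these compounds, whether a fluorine, an amine or a longer chain such as ethoxy on this same carbon would also lower the number stays open.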